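Moving from a methyl to a chloro indazole on the cytotoxicity series

A few compounds are considered here, and "the series" means these few. Any claim that something is new, unique, unknown or untested is made for them only; others in the source may bear on it.

Of the compounds shown here, three share a core and have been tested in a functional assay on MCF7 cells (Homo sapiens) for cytotoxicity, read by CellTiter-Glo, with a stated time of 5 days; a higher number here means a weaker inhibitor, a lower number a stronger inhibitor. Compound 1 `O=C(O)/C=C/c1ccc(/C(=C(\c2ccccc2)C2CCCC2)c2ccc3[nH]ncc3c2)cc1` gives 10 nM. Among the compounds with values here, compound 2 `O=C(O)/C=C/c1ccc(/C(=C(\c2ccccc2)C2CCCCC2)c2ccc3[nH]ncc3c2)cc1` gives 64 nM, and the step of a 6.4-fold higher number from compound 1 to compound 2 (0.81 log units; beyond the scatter) is the only single-point change measured so far. Compound 3 `CC/C(=C(/c1ccc(/C=C/C(=O)O)cc1)c1cc2cn[nH]c2cc1C)c1ccccc1` gives 468 nM, the highest of the three numbers, standing beyond the scatter from compound 2 and further still from compound 1.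

Compound 4 `CC/C(=C(/c1ccc(/C=C/C(=O)O)cc1)c1cc(Cl)c2[nH]ncc2c1)c1ccccc1` has not yet been measured. It differs from compound 3 in one place: 7-chloro-1H-indazol-5-yl in place of 6-methyl-1H-indazol-5-yl on a double-bonded chain carbon bound to an aromatic carbon and a double-bonded chain carbon. Within the data shown here, no measured step concerns this kind of exchange; the one step on record, from compound 1 to compound 2, swaps a saturated ring and tells nothing about an indazole substituent. Compounds 1 and 2 carry an unsubstituted indazole and give lower numbers than compound 3, but they also differ from compound 3 elsewhere, so no clean reading is possible. He therefore expects compound 4 to land near compound 3, with a wide margin, and estimates 250 nM within 60 nM to 1000 nM, a step of a 1.9-fold lower number from compound 3 to compound 4 (0.27 log units; within the scatter) that is itself expected rather than known.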

Compound 4, half-maximal inhibitory concentration: 56 nM
Compound 4: middle estimate off by 4.5-fold (0.65 log units), on the high side; measured number below the stated range.
By their numbers in this assay, from the lowest: compound 1; then compounds 4 and 2 (each within the scatter of the next); then compound 3.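

In this assay, within the data shown here, 7-chloro-1H-indazol-5-yl in place of 6-methyl-1H-indazol-5-yl gives an 8.4-fold lower number from compound 3 to compound 4 (0.92 log units; beyond the scatter), the first measured step that concerns a substituent on the indazole rather than a saturated ring. The two groups have the same number of heavy atoms and the same ring, hydrogen-bond donor and hydrogen-bond acceptor counts, yet the step lies beyond the scatter, so this place on the double-bonded chain carbon responds to a change that leaves those counts untouched. The exchange removes the methyl and brings in the chloro at a different number on the indazole name, and no measurement given here accounts for the size of the step.

The compounds shown leave open how much of the step belongs to losing the methyl, how much to gaining the chloro, and how much to where each group sits, since an unsubstituted indazole appears only on the cores of compound 1 and compound 2, which differ elsewhere. They also leave open whether a fluoro or a methoxy group in place of the chloro would behave alike, and whether the chloro would have a similar effect on the core of compound 1.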